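Testing a (Methylamino)ethyl Chain on the Sulfur

This account rests on a few compounds, and the source may have more. Where it says the series, first, only, none or still open, it means among the compounds named here.

Three compounds have been measured in a functional assay on HT cells (Homo sapiens) for antiproliferative activity, read by fluorescence, with a stated time of 72 h; on this read-out lower numbers stand for stronger inhibition of growth and higher numbers for weaker inhibition of growth:

Compound 1 `CC(C)c1n[nH]c2c(NCc3ccc(-c4ccccn4)cc3)nc(SCC(O)C(F)(F)F)nc12` gives 690 nM.
Compound 2 `CC(C)c1n[nH]c2c(NCc3ccc(-c4ccccn4)cc3)nc(SCC(C)(C)O)nc12` gives 507 nM.
Compound 3 `CC(C)c1n[nH]c2c(NCc3ccc(-c4ccccn4)cc3)nc(SC(C)C(C)O)nc12` gives 190 nM.

Compound 2 holds the second highest number of the three. Its nearest neighbour is compound 1, and that gap, a 1.4-fold lower number from compound 1 to compound 2 (0.13 log units; within the scatter), is within the scatter, so the two cannot be told apart. The gap to compound 3, a 2.7-fold lower number from compound 2 to compound 3 (0.43 log units; beyond the scatter), is beyond the scatter but still modest. The other measured step, a 3.6-fold lower number from compound 1 to compound 3 (0.56 log units; beyond the scatter), is also modest.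

Compound 4 `CNCCSc1nc(NCc2ccc(-c3ccccn3)cc2)c2[nH]nc(C(C)C)c2n1` carries the change ((methylamino)methyl in place of 1-hydroxy-1-methylethyl on a saturated chain carbon bound to a sulfur). Going by the values given here, none of the measured steps exchanges the hydroxy group itself for a nitrogen; they only rearrange the carbons and fluorines of the chain on the sulfur, and even then the numbers move little. Among the compounds with values here, with no direct precedent, the step in this assay is expected to be small, in either direction or none beyond the scatter.

Compound 4 is therefore estimated to give 400 nM, with a range from 130 nM to 1200 nM. This estimate means a 1.3-fold lower number from compound 2 to compound 4 (0.10 log units; within the scatter), a shift expected to remain within the scatter.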

Compound 4, concentration for 50% growth inhibition: 56 nM
For compound 4 the middle estimate is 7.1-fold (0.85 log units) above the measured one, outside the stated range (below it).
By their numbers in this assay, from the lowest: compound 4; then compound 3; then compounds 2 and 1 (each within the scatter of the next).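

In this assay, the 2-(methylamino)ethyl chain on the sulfur gives a 9.1-fold lower number from compound 2 to compound 4 (0.96 log units; beyond the scatter) and a 3.4-fold lower number from compound 3 to compound 4 (0.53 log units; beyond the scatter) and a 12-fold lower number from compound 1 to compound 4 (1.09 log units; beyond the scatter), all beyond the scatter. Compound 4 is therefore the strongest of the four, and the last of these steps is larger than any step among the hydroxy-bearing chains, so this position can respond more strongly than those compounds suggested. Nothing measured here explains why the chain with a nitrogen gives the lower number.

Compound 4 differs from compound 2 in both the nitrogen and the loss of branching, so a plain 2-hydroxyethyl chain would be needed to separate the two. As far as these compounds go, it also remains open whether a primary amine, a dimethylamine or a longer chain carrying an amine on the sulfur would give similar numbers.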